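Changing the aryl group of compound 3

This account rests on a few compounds, and the source may have more. Where it says the series, first, only, none or still open, it means among the compounds named here.

In a functional assay on KBVIN cells (Homo sapiens) for antiproliferative activity, read by sulforhodamine B assay, with a stated time of 3 days (a lower number here means that less compound is needed, a higher number that more compound is needed for the effect), compound 1 `CCC1=C(O)c2c(oc(-c3ccc(C)cc3)cc2=O)C(CC)(CC)C1=O` gives 0.08 uM, compound 2 `CCC1=C(O)c2c(oc(-c3ccc(O)cc3)cc2=O)C(CC)(CC)C1=O` gives 20.6 uM and compound 3 `CCC1=C(O)c2c(oc(-c3ccc(COC)cc3)cc2=O)C(CC)(CC)C1=O` gives 3.4 uM, the middle of the three numbers. Compound 4 `CCC1=C(O)c2c(oc(-c3ccccc3F)cc2=O)C(CC)(CC)C1=O` keeps the shared core but exchanges the whole aromatic group: 2-fluorophenyl in place of 4-(methoxymethyl)phenyl on an aromatic carbon. Among the measured compounds shown here, no measured step makes this exact change. The closest evidence comes from smaller edits to the same group, which moved the number widely: a 260-fold higher number from compound 1 to compound 2 (2.41 log units; beyond the scatter), a 43-fold higher number from compound 1 to compound 3 (1.63 log units; beyond the scatter) and a 6.1-fold lower number from compound 2 to compound 3 (0.78 log units; beyond the scatter). Large steps are therefore possible in either direction, and the lowest number, from compound 1 at 0.08 uM, shows how far this group can take it. With little certainty, the expected modest drop is a 2.3-fold lower number from compound 3 to compound 4 (0.36 log units; beyond the scatter). Compound 4 is estimated at 1.5 uM, with an expected range of 0.15 uM to 15 uM.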

Compound 4, concentration for half-maximal effect: 3.93 uM
The estimate for compound 4 lay 2.6-fold (0.42 log units) below the measured number, within the range that was stated.
By their numbers in this assay, from the lowest: compound 1; then compounds 3 and 4 (each within the scatter of the next); then compound 2.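

Exchanging 4-(methoxymethyl)phenyl for 2-fluorophenyl gives a 1.2-fold higher number from compound 3 to compound 4 (0.06 log units; within the scatter) in this assay, so two groups differing in size and in hydrogen-bond acceptors can give numbers within the scatter of each other. The 2-fluorophenyl group still stands well apart from the other two groups, with a 5.2-fold lower number from compound 2 to compound 4 (0.72 log units; beyond the scatter) and with a 49-fold higher number from compound 1 to compound 4 (1.69 log units; beyond the scatter) as the largest of these steps. No supporting evidence accounts for these differences. The compounds shown leave open how 4-ethylphenyl or 4-aminophenyl would compare. They also leave open whether 2-methylphenyl would match the low number of compound 1.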